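Isoquinolin-3-yl replaced by 1,3-benzothiazol-2-yl

The compounds below may be only part of what the source reports. "The series", "measured", "known", "first", "only" and "open" are said of these compounds alone.

Values in a functional assay for inhibition, with Homo sapiens as the target (a higher number here means a weaker inhibitor, a lower number a stronger inhibitor), are these:
Compound 1 `CC(C)(C)Sc1c(CC(C)(C)C(=O)O)n(Cc2ccc(Cl)cc2)c2ccc(CCc3ccc4ccccc4n3)cc12` gives 4 nM
Compound 2 `CC(C)(C)Sc1c(CC(C)(C)C(=O)O)n(Cc2ccc(Cl)cc2)c2ccc(OCc3cc4ccccc4cn3)cc12` gives 3 nM

For the measured compounds named here, compound 2 cannot be separated from its only measured neighbour: a 1.3-fold lower number from compound 1 to compound 2 (0.12 log units; within the scatter) is the sole step known. Compound 3 `CC(C)(C)Sc1c(CC(C)(C)C(=O)O)n(Cc2ccc(Cl)cc2)c2ccc(OCc3nc4ccccc4s3)cc12` carries 1,3-benzothiazol-2-yl in place of isoquinolin-3-yl on a saturated chain carbon bound to an oxygen on an aromatic ring on a saturated chain carbon bound to an oxygen on an aromatic ring. Going by the values given here, the one measured step, made on an aromatic carbon, does not cover this change directly. With compound 2 at 3 nM as the reference, no shift beyond the scatter is expected in this assay for this change. The expected move is a 1.3-fold higher number from compound 2 to compound 3 (0.12 log units; within the scatter) in size. Compound 3 is estimated at 4 nM (range 1.5 nM to 12 nM).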

Compound 3, half-maximal inhibitory concentration: 3 nM
Beside the measured number, compound 3's estimate is 1.3-fold (0.12 log units) above it; the measured number falls inside the stated range.
By their numbers in this assay, from the lowest: compounds 2, 3 and 1 (each within the scatter of the next).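

In this assay, 1,3-benzothiazol-2-yl in place of isoquinolin-3-yl gives no change at the digits printed from compound 2 to compound 3 (within the scatter) on this saturated chain carbon bound to an oxygen on an aromatic ring, so 1,3-benzothiazol-2-yl can stand here with no shift beyond the scatter. Set against 2-(quinolin-2-yl)ethyl, (1,3-benzothiazol-2-yl)methoxy gives a 1.3-fold lower number from compound 1 to compound 3 (0.12 log units; within the scatter) as well. No evidence is available on why these values lie so close.

All three compounds carry a fused pair of aromatic rings at this end. From the compounds shown here alone, whether a single ring such as phenyl or pyridin-2-yl, or a simple amine on the same chain carbon, would hold up in this assay remains open.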